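Swapping a Saturated Ring for an Aromatic Bicycle

A few compounds are considered here, and "the series" means these few. Any claim that something is new, unique, unknown or untested is made for them only; others in the source may bear on it.

Measured compounds:
- Compound 1, `Cc1cc(OCC2(O)CCS(=O)(=O)CC2)cc(C)c1-c1cccc(COc2ccc3c(c2)OC[C@H]3CC(=O)O)c1`: 13 nM
- Compound 2, `Cc1cc(OCCCS(C)(=O)=O)c(Cl)c(C)c1-c1cccc(COc2ccc3c(c2)OC[C@H]3CC(=O)O)c1`: 16 nM

Two compounds share a common core and differ only in the group on the ether chain. In a functional assay on CHO cells for agonist activity at Free fatty acid receptor 1 (Homo sapiens), read by FLIPR and calcium flux, with a stated time of 90 s, in the presence of a further agent that is not named here (a higher number here means that more compound is needed for the effect, a lower number that less compound is needed), compound 1 gives 13 nM, the lowest of the two numbers, while compound 2 gives 16 nM; the two values lie within the scatter of each other, so neither can be called the more potent one.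

Compound 3, `Cc1cc(OCc2cccc3nccn23)cc(C)c1-c1cccc(COc2ccc3c(c2)OC[C@H]3CC(=O)O)c1`, has not yet been measured in this assay. It differs from compound 1 in one place: a group of 9 heavy atoms (7 carbon, 2 nitrogen; one five-membered aromatic ring with 2 hetero atoms, one six-membered aromatic ring with 1 hetero atom) in place of a group of 9 heavy atoms (5 carbon, 3 oxygen, 1 sulfur; one six-membered non-aromatic ring with 1 hetero atom), on a saturated chain carbon bound to an oxygen on an aromatic ring. Among the measured compounds shown here, no step between two measured compounds is available to guide this change, so the expectation rests on the values of compound 1 and compound 2 alone, both of which sit close together. The step from compound 1 to compound 3 is expected to be small, with a modest shift toward a higher number as the more likely direction, a 1.9-fold higher number from compound 1 to compound 3 (0.28 log units; within the scatter). Compound 3 is estimated at 25 nM, with a range from 8 nM to 80 nM.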

Compound 3, half-maximal effective concentration in the Free fatty acid receptor 1 assay: 17 nM
Compound 3: middle estimate off by 1.5-fold (0.17 log units), on the high side, within the range that was stated.
By their numbers in the Free fatty acid receptor 1 assay, from the lowest: compounds 1, 2 and 3 (each within the scatter of the next).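

In the Free fatty acid receptor 1 assay, the group with one five-membered and one six-membered aromatic ring stands in for 4-hydroxy-1,1-dioxothian-4-yl at this saturated chain carbon without a readable difference: the result is a 1.3-fold higher number from compound 1 to compound 3 (0.12 log units; within the scatter). In a physicochemical assay for lipophilicity, read by HPLC, at pH 7.4 (a lower number here means a more polar compound, a higher number a more lipophilic compound), compound 1 gives 2.43 and compound 3 gives 3.8, which is a number 1.37 log units higher from compound 1 to compound 3 (beyond the scatter). Compound 3 is thus the more lipophilic compound, while the Free fatty acid receptor 1 assay does not separate it from compound 1: the measured distribution coefficient of compound 1, 2.43, and of compound 3, 3.8, a number 1.37 log units higher (beyond the scatter)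

Whether a plain phenyl ring or a morpholine on this carbon would also stay within the scatter of compound 1 in the Free fatty acid receptor 1 assay cannot be read from these compounds. Compound 2 differs from compound 1 in more than one place, so it cannot settle this question.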